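Replacing a dichlorophenyl amide with an ethyl oxamate

The compounds below may be only part of what the source reports. "The series", "measured", "known", "first", "only" and "open" are said of these compounds alone.

Compound 1 `COc1cc(/C=C/C(=O)c2cccc(NC(=O)c3c(Cl)cccc3Cl)c2)ccc1O` carries a 2,6-dichlorophenyl on the amide carbonyl of the shared core. In a functional assay on U-87MG ATCC cells (Homo sapiens) for inhibition (a higher number here means a weaker inhibitor, a lower number a stronger inhibitor), compound 1 gives 17.8 ug/mL. Among the compounds with values here, its only measured neighbour, compound 2 `COC(=O)C(=O)Nc1cccc(C(=O)/C=C/c2ccc(O)c(OC)c2)c1`, gives 12.2 ug/mL in this assay; the two numbers sit within the usual scatter of each other, so compound 1 is set apart from nothing by more than that. Within the data shown here, the step of a 1.5-fold lower number from compound 1 to compound 2 (0.16 log units; within the scatter) is the one comparison that bears on the change now considered. Compound 3 `CCOC(=O)C(=O)Nc1cccc(C(=O)/C=C/c2ccc(O)c(OC)c2)c1` differs from compound 1 as follows: ethoxycarbonyl in place of 2,6-dichlorophenyl on a carbonyl carbon. Because the step of a 1.5-fold lower number from compound 1 to compound 2 (0.16 log units; within the scatter) exchanged the same 2,6-dichlorophenyl for a methoxycarbonyl without moving beyond the scatter, a step of similar size, a 1.4-fold lower number from compound 1 to compound 3 (0.14 log units; within the scatter), is expected here, toward a lower number but not clearly beyond the scatter. Compound 3 is therefore estimated at 13 ug/mL in this assay, with a range from 7 ug/mL to 25 ug/mL.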

Compound 3, half-maximal inhibitory concentration: > 50 ug/mL
Compound 3 was reported as a limit; the forecaster's own chance of this, stated with the estimate: 5%; at least 3.8-fold (0.58 log units) between middle value and limit.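

At this position, a small difference in the group on the carbonyl carbon separates the outcomes, which the earlier pair could not show: ethoxycarbonyl in place of 2,6-dichlorophenyl gives an at least 2.8-fold higher number from compound 1 to compound 3 (0.44 log units; beyond the scatter), whereas methoxycarbonyl had stayed within the scatter. In this assay, methyl in place of hydrogen on the saturated chain carbon gives an at least 4.0-fold higher number from compound 2 to compound 3 (0.61 log units; beyond the scatter), so these two esters are not interchangeable here. Compound 3 is reported only as a limit of the assay, so both steps are minimum sizes: the limit of > 50 ug/mL in this assay, at which 1 of the 3 values shown sits.

On these data alone, the actual size of these steps stays open. So does the question of whether a carboxylic acid or a propoxycarbonyl in place of the ethoxycarbonyl would fall with compound 2 or with compound 3.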